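Shortening the iodoacetamide linker on the shared core

The compounds below may be only part of what the source reports. "The series", "measured", "known", "first", "only" and "open" are said of these compounds alone.

The series is two nucleotide triphosphates carrying an iodoacetamide at the end of an alkyl chain on the shared core. Compound 1 `O=C(CI)NCCCCCCCCNc1ncnc2c1ncn2[C@@H]1O[C@H](COP(=O)(O)OP(=O)(O)OP(=O)(O)O)[C@@H](O)[C@H]1O` places the chain on the exocyclic nitrogen of the core, and in an assay on isolated protein for inhibition of hexokinase-1 (Rattus norvegicus), with a stated time of 6 h, tested at 10 mM (a higher number here means more inhibition at the concentration tested (going by the name of the read-out), a lower number less inhibition), compound 1 gives 35%. Compound 2 `Nc1ncnc2c1nc(NCCCCNC(=O)CI)n2[C@@H]1O[C@H](COP(=O)(O)OP(=O)(O)OP(=O)(O)O)[C@@H](O)[C@H]1O` carries its chain at a different position of the core, and in this assay compound 2 gives 0%, the lowest of the two numbers, with compound 1 higher by an amount beyond the usual scatter.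

Compound 3 `Nc1ncnc2c1nc(NCCNC(=O)CI)n2[C@@H]1O[C@H](COP(=O)(O)OP(=O)(O)OP(=O)(O)O)[C@@H](O)[C@H]1O` differs from compound 2 in one place: ((iodomethyl)carbonyl)amino in place of 2-(((iodomethyl)carbonyl)amino)ethyl on a saturated chain carbon, two bonds along the chain from a nitrogen on an aromatic ring. Going by the values given here, no measured pair shows a step of this kind, so the direction rests on compound 2 alone. Because compound 2 gives 0% and only the chain length changes, the step of a number 5 percentage points higher from compound 2 to compound 3 (within the scatter) is expected to be small, most likely none beyond the scatter, with any movement upward since the number cannot fall further. In this assay compound 3 is expected to give 5%, within a range from 0% to 25%.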

Compound 3, a percentage reported as inhibition, at one concentration (the size of the read-out at that concentration, not a potency): 0%
Beside the measured number, compound 3's estimate is 5 percentage points above it, and the stated range covers the measured number.
By their numbers in this assay, from the lowest: compounds 2 and 3 (each within the scatter of the next); then compound 1.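

In this assay the change from 2-(((iodomethyl)carbonyl)amino)ethyl to ((iodomethyl)carbonyl)amino, on a saturated chain carbon, two bonds along the chain from a nitrogen on an aromatic ring, gives no change at the digits printed from compound 2 to compound 3 (within the scatter) and so adds no measurable inhibition at this position. With compound 3 at 0% as well, two chain lengths at this position now sit at the bottom of the read-out, where any loss from the shortening could not register, so the step shows only that this shorter chain does not lift the number. Nothing measured on these compounds bears on why the two chain lengths read alike.

Still open, as far as these compounds go, is whether a longer chain at this position, or a bromoacetamide or an acrylamide at the chain end in place of the iodoacetamide, would bring the number up from the bottom of the read-out. Compound 1 differs from compound 2 in both chain length and chain placement, so the shown compounds do not separate the two, and a shorter chain with the placement of compound 1 would be needed to do so.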